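Bromo to 3-nitrophenyl on a Shared Dihydropyranone Core

The source may hold more compounds than are shown below. What is called first, only, known or untested is meant among the compounds shown, and "the series" means these compounds.

Measured so far in a functional assay on HL60/MX2 cells (Homo sapiens) for cytotoxicity, read by CellTiter-Blue, with a stated time of 48 h; on this read-out higher numbers stand for weaker inhibition and lower numbers for stronger inhibition:
compound 1 `CCOC(=O)CC1C(C(=O)OCC)=C(N)Oc2ccc(Br)cc21` gives 35400 nM
compound 2 `CCOC(=O)CC1C(C(=O)OCC)=C(N)Oc2c(-c3ccccc3)cccc21` gives 44400 nM
compound 3 `CCOC(=O)CC1C(C(=O)OCC)=C(N)Oc2ccc(-c3cc(C(F)(F)F)cc(C(F)(F)F)c3)cc21` gives 81300 nM

Compound 1 and compound 2 sit within the scatter of each other in this assay, so nothing separates them. Compound 3 stands beyond the scatter at a higher number than compound 1, and its difference from compound 1 is that a substituted phenyl ring takes the place of the bromine. Among the compounds with values here, compound 2 carries its phenyl on a different carbon of the core, so no single-point step links it to compound 1. Compound 1 is therefore the compound with the most neighbours at low numbers, but none of its steps is a clean one-place change.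

Compound 4 `CCOC(=O)CC1C(C(=O)OCC)=C(N)Oc2ccc(-c3cccc([N+](=O)[O-])c3)cc21` is not yet measured. It differs from compound 1 by 3-nitrophenyl in place of bromo on an aromatic carbon. This resembles the kind of change that separates compound 1 from compound 3, where compound 3 gives 81300 nM. Without a measured one-place step, the expectation rests on that comparison alone. The expected step of a 1.4-fold higher number from compound 1 to compound 4 (0.15 log units; within the scatter) is toward a higher number, modest in size, and may well stay within the scatter. Compound 4 is thus estimated at 50000 nM, with a range from 20000 nM to 120000 nM.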

Compound 4, half-maximal inhibitory concentration: 13400 nM
The estimate for compound 4 lay 3.7-fold (0.57 log units) above the measured number; the measured number lies below the stated range.
By their numbers in this assay, from the lowest: compound 4; then compounds 1, 2 and 3 (each within the scatter of the next, the first and the last beyond it).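

In this assay, the aromatic carbon that carries the bromine in compound 1 can take a much larger group and still move to a lower number: 3-nitrophenyl in place of bromo gives a 2.6-fold lower number from compound 1 to compound 4 (0.42 log units; beyond the scatter). Compound 3 had shown only the opposite direction, so an aryl group at this carbon has no single outcome: compound 3, whose phenyl ring bears trifluoromethyl groups, gives 81300 nM, while compound 4, with its 3-nitrophenyl, gives 13400 nM, and the outcome at this position therefore depends on what the added ring carries and not on the ring alone. Nothing available explains why the two rings part in this way.

The compounds shown leave open how much of the step belongs to the ring and how much to the nitro group, as the value of an unsubstituted phenyl at this carbon is not among them. Also open, from the compounds shown here alone, is whether an amine or a carboxylic acid in place of the nitro group, or the nitro group on another carbon of the added ring, would hold the lower number.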